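Working notes: 2,6-dihydroxyphenyl in place of 2,4-dihydroxyphenyl on the shared core

This account rests on a few compounds, and the source may have more. Where it says the series, first, only, none or still open, it means among the compounds named here.

In a functional assay on HepG2 cells (Homo sapiens) for inhibition, read by MTT assay, with a stated time of 72 h (on this read-out lower numbers stand for an effect already at smaller amounts and higher numbers for an effect only at larger amounts of compound), compound 1 `CC1(C)CCC[C@]2(C)[C@@H](Cc3cc(C(=O)O)ccc3O)[C@](C)(O)CC[C@@H]12` gives > 50000 nM, which is a limit of the assay and not a number. Going by the values given here, compound 2 `CC1(C)CCC[C@]2(C)[C@@H](Cc3ccc(O)cc3O)[C@](C)(O)CC[C@@H]12` gives 10200 nM, the only true number so far, so its standing rests on that single value.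

The next compound is compound 3 `CC1(C)CCC[C@]2(C)[C@@H](Cc3c(O)cccc3O)[C@](C)(O)CC[C@@H]12`, with 2,6-dihydroxyphenyl in place of 2,4-dihydroxyphenyl on a saturated chain carbon bound to a saturated ring carbon. Among the compounds with values here, no measured pair differs in one place, so the data give no direct guide to this change. The two compounds have the same atoms, joined differently, and in this assay little beyond the scatter is expected, if anything towards a higher number. The expected step is a 1.3-fold higher number from compound 2 to compound 3 (0.11 log units; within the scatter). Compound 3 is estimated at 13000 nM, with an expected range of 5000 nM to 35000 nM.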

Compound 3, half-maximal effective concentration: 13900 nM
Compound 3: middle estimate off by 1.1-fold (0.03 log units), on the low side; the range from low to high includes it.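

Working from the shared core, this assay now holds its first readable step for 2,6-dihydroxyphenyl in place of 2,4-dihydroxyphenyl on a saturated chain carbon bound to a saturated ring carbon: a 1.4-fold higher number from compound 2 to compound 3 (0.13 log units; within the scatter). For this pair, rearranging the two hydroxyl groups on the aromatic ring, with the same atoms and the same counts of donors and acceptors, therefore moves the read-out no further than the scatter. Both compounds carry true numbers, so this comparison does not rest on the one value in the series that is a limit: the limit of > 50000 nM in this assay, at which 1 of the 3 values shown sits.

Going by these compounds, what a methoxy group or an amine in place of either hydroxyl group would do in this assay stays open. So does the effect of a longer chain at the saturated chain carbon, and a single pair cannot show whether the same result would hold on any other core.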